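Hydroxycarbamoyl series: liver-cell cytotoxicity working notes

The compounds below may be only part of what the source reports. "The series", "measured", "known", "first", "only" and "open" are said of these compounds alone.

Measured so far in an ADME assay on Huh-7 cells (Homo sapiens) for cytotoxicity, read by MTT assay, with a stated time of 72 h; on this read-out higher numbers stand for lower toxicity in this test and lower numbers for higher toxicity in this test:
compound 1 `O=C(NO)c1ccccc1Cl`: 330000 nM
compound 2 `O=C(NO)c1ccccc1[N+](=O)[O-]`: 55000 nM
compound 3 `COCc1ccccc1C(=O)NO`: > 1000000 nM, a limit of the assay

Compound 3 sits at the top of the set; its value is only a limit (the limit of > 1000000 nM in this assay, at which 1 of the 3 values shown sits). The steps that lead to it are an at least 3.0-fold higher number from compound 1 to compound 3 (0.48 log units; beyond the scatter) and an at least 18-fold higher number from compound 2 to compound 3 (1.25 log units; beyond the scatter), both pointing the same way, while a 6.0-fold lower number from compound 1 to compound 2 (0.78 log units; beyond the scatter) runs the other way. Compound 4 `CCCCOc1ccccc1C(=O)NO` differs from compound 3 by butoxy in place of methoxymethyl on an aromatic carbon. For the measured compounds named here, no measured step covers a butoxy group, so the change is judged only from where compound 3 stands. In this assay compound 4 is expected to remain near the limit, with a step of a number no higher from compound 3 to compound 4 (the limit leaves the size open) that is not beyond the scatter. The estimate for compound 4 is 1000000 nM, with a range of 400000 nM to 3000000 nM.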

Compound 4, half-maximal cytotoxic concentration: 380000 nM
The estimate for compound 4 lay 2.6-fold (0.42 log units) above the measured number; measured number below the stated range.
By their numbers in this assay, from the lowest: compound 2; then compounds 1 and 4 (each within the scatter of the next). At a limit, above all of these: compound 3.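

In this assay, butoxy in place of methoxymethyl on this aromatic carbon gives an at least 2.6-fold lower number from compound 3 to compound 4 (0.42 log units; beyond the scatter), so keeping one oxygen in the substituent does not by itself hold the number at the top of the set. Butoxy gives a 6.9-fold higher number from compound 2 to compound 4 (0.84 log units; beyond the scatter), while a 1.2-fold higher number from compound 1 to compound 4 (0.06 log units; within the scatter) leaves butoxy and chloro not separable in this test. Compound 3 remains a limit, so the size of its step stays open: the limit of > 1000000 nM in this assay, at which 1 of the 4 values shown sits.

From the compounds shown here alone, whether chain length or the placement of the oxygen separates butoxy from methoxymethyl stays open. Going by these compounds, what a methoxy group or an amine on this aromatic carbon would give also stays open.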